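Shrinking the Amine: From Compound 2 to Compound 3

The source may report more compounds than this note shows. Statements on the series, on what has been measured and on what is new or still open speak of the compounds shown alone.

Measured so far:
compound 1 `CCCN(CCC)Cc1ccc(Cl)c(-c2ccccc2OC)c1`: > 10000 nM
compound 2 `COc1ccccc1-c1cc(CN(C)C)ccc1Cl`: 4100 nM

For the measured compounds named here, in an assay on isolated protein for binding affinity to 5-hydroxytryptamine receptor 1E (Homo sapiens) (a lower number here means a stronger inhibitor, a higher number a weaker inhibitor), compound 2 gives 4100 nM, the one actual number in this set. Compound 1 reaches only a limit of the assay, > 10000 nM; (the limit of > 10000 nM in this assay, at which 1 of the 2 values shown sits). The measured step, an at least 2.4-fold lower number from compound 1 to compound 2 (0.38 log units; beyond the scatter), shows that a smaller amine gave the stronger binder. Compound 3 `CCCCNCc1ccc(Cl)c(-c2ccccc2OC)c1` carries butylamino in place of dimethylamino on a saturated chain carbon bound to an aromatic carbon. That change moves back toward a longer chain, though shorter than in compound 1, so the step expected here is a 1.5-fold higher number from compound 2 to compound 3 (0.17 log units; within the scatter). Compound 3 is therefore estimated at 6000 nM, with a range of 2000 nM to 20000 nM.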

Compound 3, inhibition constant: > 10000 nM
Compound 3 ended at the assay's limit (the forecaster's own chance of this, stated with the estimate: 30%); middle value at least 1.6-fold (0.22 log units) away from the limit.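

In this assay, butylamino in place of dimethylamino gives an at least 2.4-fold higher number from compound 2 to compound 3 (0.38 log units; beyond the scatter), so a secondary amine with one longer chain also binds more weakly, not only the dipropylamino of compound 1. Of the three amines shown, only dimethylamino gives a readable number. The step between the two weaker compounds cannot be read, since both values are limits: the limit of > 10000 nM in this assay, at which 2 of the 3 values shown sit.

Open, on these data alone, is whether the longer chain or the added hydrogen-bond donor accounts for the weaker binding. Methylamino, which has the donor on a shorter chain, could help separate the two.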